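Benzothiazole replaced by an amide at the chloro-bearing ring

The source may report more compounds than this note shows. Statements on the series, on what has been measured and on what is new or still open speak of the compounds shown alone.

Compound 1 `Cc1nc(C(F)(F)F)ccc1C(=O)Nc1ccc(Cl)c(-c2cc3ccccc3[nH]2)c1` and compound 2 `Cc1nc(C(F)(F)F)ccc1C(=O)Nc1ccc(Cl)c(-c2nc3ccccc3s2)c1` share a core and differ only at one aromatic carbon. In an assay on C3H 10T1/2 cells for inhibition of Sonic hedgehog protein (Mus musculus), read by a luciferase reporter (a higher number here means a weaker inhibitor, a lower number a stronger inhibitor), compound 1 gives 500 nM, and compound 2 gives 70 nM, the lowest of the two numbers shown; the step of a 7.1-fold lower number from compound 1 to compound 2 (0.85 log units; beyond the scatter) lies beyond the scatter. Compound 3 `Cc1nc(C(F)(F)F)ccc1C(=O)Nc1ccc(Cl)c(C(=O)Nc2ccccc2)c1` carries the change (phenylcarbamoyl in place of 1,3-benzothiazol-2-yl on an aromatic carbon). Going by the values given here, no measured step has this group entering or leaving, so the only guide is that the step from compound 1 to compound 2 showed this position to matter. The entering group keeps the size but not the ring pattern, so a weaker inhibitor than compound 2 is expected, with the estimated step of an 8.6-fold higher number from compound 2 to compound 3 (0.93 log units; beyond the scatter) carrying wide uncertainty. Compound 3 is therefore estimated at 600 nM, within a range from 100 nM to 4000 nM.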

Compound 3, half-maximal inhibitory concentration: 140 nM
Compound 3: the middle estimate sits 4.3-fold (0.63 log units) above what was measured, within the range that was stated.
By their numbers in this assay, from the lowest: compounds 2 and 3 (each within the scatter of the next); then compound 1.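

In this assay, going by these compounds alone, the change shows a 2.0-fold higher number from compound 2 to compound 3 (0.30 log units; within the scatter) when phenylcarbamoyl replaces 1,3-benzothiazol-2-yl, so at this position an open amide carrying one six-membered aromatic ring cannot be told apart from the two-ring group that gave the lowest number so far. The difference seen earlier is therefore not unique to 1,3-benzothiazol-2-yl, since the step of a 3.6-fold lower number from compound 1 to compound 3 (0.55 log units; beyond the scatter) also sets phenylcarbamoyl apart from 1H-indol-2-yl in the same direction. Nothing available accounts for these differences or explains why the two groups match.

Still open, on these data alone, is whether the amide hydrogen matters at this position, a question that a methyl group on the amide nitrogen would address. As far as these compounds go, it is also open whether the phenyl ring can give way to a pyridine ring or to a benzyl group.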